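Hydroxy step on a flat three-compound series

The source may report more compounds than this note shows. Statements on the series, on what has been measured and on what is new or still open speak of the compounds shown alone.

compound 1 `O=C1NC(=O)c2c1c1c(c3[nH]c4ccccc4c23)C(=O)CCC1` gives 15500 nM
compound 2 `O=C1CCc2c1c1c(c3c2[nH]c2ccccc23)C(=O)NC1=O` gives 16100 nM
compound 3 `O=c1ccc(=O)c2c1c1[nH]c3ccccc3c1c1c(=O)[nH]c(=O)c21` gives 17400 nM

In a functional assay on HT-29 cells (Homo sapiens) for antiproliferative activity, with a stated time of 4 h (on this read-out lower numbers stand for stronger inhibition and higher numbers for weaker inhibition), compound 3 stands within the scatter of both compound 2 and compound 1, so no order among the three can be read from these numbers. Compound 4 (`O=c1ccc(=O)c2c1c1[nH]c3ccc(O)cc3c1c1c(=O)[nH]c(=O)c21`) keeps the core of compound 3 with one change (hydroxy in place of hydrogen on an aromatic carbon): hydroxy in place of hydrogen on an aromatic carbon, on a six-membered aromatic ring of carbon only, part of a fused or bridged system of five rings. For the measured compounds named here, no two measured compounds differ in a single place, so the data give no direct size for such a step. Compounds 1, 2 and 3 differ in their cores, yet their values lie within the scatter of each other. A modest move (a 1.9-fold lower number from compound 3 to compound 4 (0.29 log units; within the scatter)) toward a lower number is expected in this assay, of a size close to the scatter, and its direction remains a judgement. The estimate for compound 4 is 9000 nM (expected range 2500 nM to 25000 nM) on this read-out.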

Compound 4, half-maximal inhibitory concentration: 50600 nM
Compound 4: the middle estimate sits 5.6-fold (0.75 log units) below what was measured; measured number outside the range, above it.
By their numbers in this assay, from the lowest: compounds 1, 2 and 3 (each within the scatter of the next); then compound 4.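

In this assay, hydroxy in place of hydrogen on this aromatic carbon gives a 2.9-fold higher number from compound 3 to compound 4 (0.46 log units; beyond the scatter). For the compounds shown here, this is the first single-place step that can be sized, and it lies beyond the scatter, so this carbon of the six-membered aromatic ring is not indifferent to substitution, and the change runs toward weaker inhibition. Nothing available bears on why the hydroxy step runs in this direction.

Going by these compounds, whether the weaker inhibition belongs to hydroxy itself or to any group at this carbon stays open, and a methoxy, an amine or a fluorine at the same place would separate these cases. One step on one core also leaves open how the same change behaves at other carbons of this ring or on the cores of compound 1 and compound 2.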